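From Benzyl Urea to Diethyl Urea on a Shared Core

A few compounds are considered here, and "the series" means these few. Any claim that something is new, unique, unknown or untested is made for them only; others in the source may bear on it.

The series shares one core, first seen in compound 1 `COc1ccc(/C(=C(/CCN=[N+]=[N-])c2ccccc2)c2ccccc2)cc1`. In a functional assay on MCF7 cells (Homo sapiens) for cytotoxicity, read by MTT assay, with a stated time of 72 h (on this read-out higher numbers stand for weaker inhibition and lower numbers for stronger inhibition), compound 1 gives "not active" (no number reported). Compound 2 `CCOC(=O)C(=O)NCC/C(=C(\c1ccccc1)c1ccc(OC)cc1)c1ccccc1` varies the side chain of that core. In this assay compound 2 reaches only the limit of the measurement, > 50000 nM. Compound 3 `COc1ccc(/C(=C(/CCNC(=O)NCc2ccccc2)c2ccccc2)c2ccccc2)cc1` carries a benzylamino group on the carbonyl carbon of its chain. In this assay compound 3 likewise reaches only the limit, > 50000 nM. The step that the two limits leave unreadable from compound 2 to compound 3 therefore cannot be read, because both ends sit at the limit of > 50000 nM in this assay, at which 2 of the 3 values shown sit. Compound 3 thus stands at the limit, as compound 2 does, while compound 1 has no number at all.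

Compound 4 `CCN(CC)C(=O)NCC/C(=C(\c1ccccc1)c1ccc(OC)cc1)c1ccccc1` differs from compound 3 in one place: diethylamino in place of benzylamino on a carbonyl carbon. For the measured compounds named here, no measured step bears on this change; the single step recorded is unreadable at both ends. With two of three values at the limit and the third without a number, compound 4 is expected to remain at the limit, with no movement beyond the scatter, so the step is estimated as a step that the limit leaves unreadable from compound 3 to compound 4. Compound 4 is therefore estimated at 60000 nM, within 30000 nM to 200000 nM.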

Compound 4, half-maximal inhibitory concentration: > 50000 nM
Compound 4: only a limit was reported; the forecaster's own chance of this, stated with the estimate: 85%; the middle value does not contradict the limit.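

The result for compound 4 in this assay is a limit and not a number, as are those for compound 2 and compound 3, so no new step can be read among these three compounds: the limit of > 50000 nM in this assay, at which 3 of the 4 values shown sit. The compounds shown leave open how far each lies from that limit, and which side chain on the shared core would give a measurable value.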